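The compounds below may be only part of what the source reports. "The series", "measured", "known", "first", "only" and "open" are said of these compounds alone.

Working notes on the series. Compound 1 `CC1CC/C(=N\Nc2ccccc2Br)c2ncc(C(=O)O)c(=O)n21` and compound 2 `CCOc1ccc(N/N=C2\CCC(C)n3c2ncc(C(=O)O)c3=O)cc1` share one core; compound 3 `CCc1ccc(N/N=C2\CCC(C)n3c2ncc(C(=O)O)c3=O)cc1` has not been measured. In a functional assay on the whole organism for inhibition, with Rattus norvegicus as the target (a higher number here means that more compound is needed for the effect, a lower number that less compound is needed), compound 1 gives only a limit of > 320 umol/kg. In this assay compound 2 also gives only a limit, > 100 umol/kg; on the numbers shown it stands at the limit of > 100 umol/kg in this assay, at which 1 of the 2 values shown sits, and no measured step connects it to any other compound. Compound 3 differs from compound 2 by ethyl in place of ethoxy on an aromatic carbon. Going by the values given here, with no measured step to lean on, no change beyond the scatter is expected, the step that the limit leaves unreadable from compound 2 to compound 3 being an expectation only. Compound 3 is estimated at 200 umol/kg, range 60 umol/kg to 600 umol/kg.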

Compound 3, dose for 50% inhibition: > 1000 umol/kg
Compound 3 was reported as a limit (the forecaster's own chance of this, stated with the estimate: 70%); middle value at least 5.0-fold (0.69 log units) from the limit.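

In this assay, going by these compounds alone, compound 1, compound 2 and compound 3 all give only limits, so no step among them can be read. As far as these compounds go, whether ethyl in place of ethoxy changes the dose needed remains open.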